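Disulfide half-life: from trichloromethyl to octyl

The source may report more compounds than this note shows. Statements on the series, on what has been measured and on what is new or still open speak of the compounds shown alone.

Measured in a physicochemical assay for metabolic stability, in the presence of a further agent that is not named here; on this read-out higher numbers stand for a longer-lived compound and lower numbers for a shorter-lived compound:
- Compound 1 `Cc1cn([C@H]2C[C@H](SSC(Cl)(Cl)Cl)[C@@H](CO)O2)c(=O)[nH]c1=O`: < 1.5 h
- Compound 2 `Cc1cn([C@H]2C[C@H](SSc3ccc([N+](=O)[O-])cc3)[C@@H](CO)O2)c(=O)[nH]c1=O`: < 0.167 h

Compound 1 gives < 1.5 h, which is a limit and not a number. Compound 2 gives < 0.167 h, which is also a limit. For the measured compounds named here, the only measured step is a step that the two limits leave unreadable from compound 1 to compound 2, with 4-nitrophenyl in place of trichloromethyl on a sulfur. Compound 3 `CCCCCCCCSS[C@H]1C[C@H](n2cc(C)c(=O)[nH]c2=O)O[C@@H]1CO` changes that same place: octyl in place of trichloromethyl on a sulfur, octyl in place of trichloromethyl. The measured step offers no size to carry over, so any forecast in this assay is loose. A modest rise is expected, with the estimated step being an at least 1.3-fold higher number from compound 1 to compound 3 (0.12 log units; that floor lies within the scatter). For compound 3 the estimated half-life is 2 h, with an expected range of 0.3 h to 12 h.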

Compound 3, half-life: < 8 h
Compound 3: a limit, no number; the forecaster's own chance of this, stated with the estimate: 35%; the middle value does not contradict the limit.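

Compound 3 gives < 8 h, which is a limit and not a number. For the compounds shown here, compound 1, compound 2 and compound 3 all carry limits, so no step between them can be read. From the compounds shown here alone, the actual half-lives, and how octyl, trichloromethyl and 4-nitrophenyl rank, remain open.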